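Trifluoromethyl in place of fluoro on the methylsulfanyl aniline

The source may report more compounds than this note shows. Statements on the series, on what has been measured and on what is new or still open speak of the compounds shown alone.

Compound 1 `CS(=O)(=O)c1ccc(F)cc1NCC1=NCCN1` in an assay on CHO cells for binding affinity to Alpha-2B adrenergic receptor (Homo sapiens), read by radioligand binding (on this read-out lower numbers stand for stronger inhibition and higher numbers for weaker inhibition), gives only a limit, < 6310 nM. Among the measured compounds shown here, compound 2 `CSc1ccc(F)cc1NCC1=NCCN1` in this assay gives 331 nM, the single number. The step that the limit leaves unreadable from compound 1 to compound 2 cannot be sized, since the limit of < 6310 nM in this assay, at which 1 of the 2 values shown sits, covers one of the two values. Compound 3 `CSc1ccc(C(F)(F)F)cc1NCC1=NCCN1` differs from compound 2 by trifluoromethyl in place of fluoro on an aromatic carbon. For the measured compounds named here, no measured step in this assay touches this change: the only step recorded concerns the methylsulfanyl-for-methylsulfonyl exchange and is itself unreadable. The expectation for compound 3 therefore rests on compound 2 alone, with 331 nM as the anchor and a wide band around it. Compound 3 is expected to give 400 nM in this assay, between 100 nM and 1600 nM. The step of a 1.2-fold higher number from compound 2 to compound 3 (0.08 log units; within the scatter) is thus estimated to stay within the scatter, with no direction claimed.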

Compound 3, inhibition constant: 1660 nM
Estimate against measurement, compound 3: 4.2-fold (0.62 log units) below; measured number outside the range, above it.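

In this assay, the aromatic carbon para to the methylsulfanyl group does not tolerate every substituent equally: trifluoromethyl in place of fluoro gives a 5.0-fold higher number from compound 2 to compound 3 (0.70 log units; beyond the scatter). Among the compounds shown here, this is the first readable step, and it gives the change at this position a size and a direction, with fluoro carrying the lower number of this single pair. Nothing shown here gives a cause for this step.

From the compounds shown here alone, with only fluoro and trifluoromethyl at this position, it remains open how a hydrogen, a methoxy group, a nitrile or an amine there would read, and whether the same change would give a similar step with methylsulfonyl in place of methylsulfanyl. The one other step in the series still cannot be read: the limit of < 6310 nM in this assay, at which 1 of the 3 values shown sits.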